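Ethyl to isopropyl on two amines of one scaffold

The source may report more compounds than this note shows. Statements on the series, on what has been measured and on what is new or still open speak of the compounds shown alone.

Compound 1, `CCN1CCN(c2cccc3nc(CN(C)[C@H]4CCCc5cccnc54)cn23)CC1`, was examined in an ADME assay on HOS cells (Homo sapiens) for cytotoxicity (on this read-out lower numbers stand for higher toxicity in this test and higher numbers for lower toxicity in this test), where compound 1 gives 3900 nM. Compound 2, `CC(C)N1CCN(c2cccc3nc(CN(C)[C@H]4CCCc5cccnc54)cn23)CC1`, carries methyl in place of hydrogen on a saturated chain carbon bound to an amine nitrogen in a ring and a saturated chain carbon and gives 7100 nM in this assay; the measured step is a 1.8-fold higher number from compound 1 to compound 2 (0.26 log units; within the scatter).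

Compound 3, `CCN(Cc1cn2c(N3CCN(C)CC3)cccc2n1)[C@H]1CCCc2cccnc21`, has the same atoms as compound 1 joined differently; the difference between the two cores is not broken down here. In this assay compound 3 gives 8100 nM, a number within the usual scatter of the value of compound 2, while the value of compound 1 lies beyond the scatter from it.

Compound 4, `CC(C)N(Cc1cn2c(N3CCN(C)CC3)cccc2n1)[C@H]1CCCc2cccnc21`, has not yet been measured. It carries methyl in place of hydrogen on a saturated chain carbon bound to an amine nitrogen and a saturated chain carbon. This is the same kind of change as that from compound 1 to compound 2, not the same change: there the place was a saturated chain carbon bound to an amine nitrogen in a ring and a saturated chain carbon, whereas here the amine nitrogen is not in a ring. Because the comparable step, a 1.8-fold higher number from compound 1 to compound 2 (0.26 log units; within the scatter), stayed within the scatter, the step from compound 3 to compound 4 is expected to be similarly small, about a 1.2-fold higher number from compound 3 to compound 4 (0.09 log units; within the scatter). Compound 4 is therefore estimated to give 10000 nM in this assay, with a range expected from 4500 nM to 22000 nM, pending the measurement.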

Compound 4, half-maximal cytotoxic concentration: 8900 nM
Compound 4: the middle estimate sits 1.1-fold (0.05 log units) above what was measured, and the stated range covers the measured number.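

In this assay, the exchange of ethyl for isopropyl on the amine nitrogen that is not in a ring gives a 1.1-fold higher number from compound 3 to compound 4 (0.04 log units; within the scatter), so this step, like the one on the ring amine, stays small. Set side by side, the two steps do not differ beyond what repeated measurements would allow: the same change on two cores in this assay, a 1.8-fold higher number (0.26 log units; within the scatter) from compound 1 to compound 2 and a 1.1-fold higher number (0.04 log units; within the scatter) from compound 3 to compound 4, 1.7-fold (0.22 log units) apart, within the scatter of two such steps This shows that, in this test, the change read the same on these two cores, but with both steps within the scatter, neither establishes a real effect of the change, and two cores whose amines also differ in being in a ring or not cannot show that it would behave alike on a further core.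

The compounds shown leave open what a larger or differently shaped group on these amines would do, such as a longer chain like butyl, a tert-butyl group or a cyclopropyl ring, or a polar one such as a carboxylic acid on the chain. They also leave open whether the ethyl to isopropyl change stays this small in any read-out other than this assay, and in particular whether the agreement between the two cores would hold there.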